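The compounds below may be only part of what the source reports. "The series", "measured", "known", "first", "only" and "open" are said of these compounds alone.

Working notes on the arylpiperazine series

Of the compounds shown here, three have been measured in a functional assay for antagonist activity at Alpha-1A adrenergic receptor (Oryctolagus cuniculus); a higher number here means weaker binding, a lower number tighter binding. Compound 1 `COc1ccccc1N1CCN(CCCNc2ncccc2C(=O)NC(C)(C)C)CC1` gives 1.26 nM. Compound 2 `COc1ccccc1N1CCN(CCCNc2ccncc2C(=O)N(C)C)CC1` gives 12.6 nM. Compound 3 `CN(C)C(=O)c1cccnc1NCCCN1CCN(c2ccccc2)CC1` gives 6.31 nM.

Compound 3 stands second highest of the three numbers. Its nearest neighbour is compound 2, whose number is higher but within the scatter, so the two cannot be told apart on this evidence. Compound 1 gives the lowest number, and its gap to compound 3 lies beyond the scatter, so compound 1 is the tighter binder of that pair.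

The next compound, compound 4 `CN(C)C(=O)c1cccnc1NCCCN1CCN(c2ccccc2Cc2ccccc2)CC1`, has not yet been measured in this assay. It differs from compound 3 in one place: benzyl in place of hydrogen on an aromatic carbon. The shared core, the dimethylamide and the three-carbon chain are unchanged.

Among the measured compounds shown here, no measured pair in this set differs by a benzyl group, so there is no directly comparable step. The benzyl group enters ortho to a large group on the phenyl ring, and a step toward a higher number, somewhat beyond the scatter, is expected for compound 4, as a 4.0-fold higher number from compound 3 to compound 4 (0.60 log units; beyond the scatter). Compound 4 is therefore estimated at 25 nM, with a range of 5 nM to 125 nM; the wide range reflects the lack of any precedent for this change among the measured compounds.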

Compound 4, dissociation constant: 6.31 nM
Compound 4: the middle estimate sits 4.0-fold (0.60 log units) above what was measured; low and high end bracket the measured number.
By their numbers in this assay, from the lowest: compound 1; then compounds 3, 4 and 2 (each within the scatter of the next).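

In this assay, benzyl in place of hydrogen on an aromatic carbon, ortho to a large group, gives no change at the digits printed from compound 3 to compound 4 (within the scatter). Among the compounds shown here, this is the first step in the set that differs in one place, and it shows that this position on the six-membered aromatic ring of carbon only tolerates a group of 7 heavy atoms, carrying a further aromatic ring, with the number staying within the scatter. The data in hand offer nothing that would account for this result.

Only one group has been read at this position, so the compounds shown leave open whether a carboxylic acid, an amine or a longer chain such as 2-phenylethyl on the same aromatic carbon would also leave the number in place. They also leave open whether benzyl at this position would give the same result in this assay alongside a different amide, such as the tert-butyl amide of compound 1, rather than the dimethylamide shared by compound 3 and compound 4.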